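Working notes: aryl variation in a maximal electroshock screen

A few compounds are considered here, and "the series" means these few. Any claim that something is new, unique, unknown or untested is made for them only; others in the source may bear on it.

Measured so far:
compound 1 `CC(C(=O)N1CCN(c2ccc(Cl)cc2)CC1)N1C(=O)CCC1=O`: 0%
compound 2 `CC(C(=O)N1CCN(c2ccccc2F)CC1)N1C(=O)CCC1=O`: 0%

In a functional assay on the whole organism (strain Swiss) with Mus musculus as the target, in the maximal electroshock model, with a stated time of 1 h, at a dose of 100 mg/kg by the intraperitoneal route (a higher number here means a stronger effect of the compound at the dose given, a lower number a weaker effect), compound 2 gives 0% and stands level with compound 1, which gives 0% in this assay. Within the data shown here, the only measured step, no change at the digits printed from compound 1 to compound 2 (within the scatter), shows no movement beyond the scatter. Compound 3 `CC(C(=O)N1CCN(c2ccc(F)cc2)CC1)N1C(=O)CCC1=O` differs from compound 2 by 4-fluorophenyl in place of 2-fluorophenyl on an amine nitrogen in a ring. Among the measured compounds shown here, that step bears on the same position as the one measured step, which was flat, so the expected step in this assay is no change at the digits printed from compound 2 to compound 3 (within the scatter), none beyond the scatter. Compound 3 is therefore estimated at 0% in this assay, with a range from 0% to 10%.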

Compound 3, a percentage reported as activity, at one dose (the size of the read-out at that dose, not a potency): 0%
Beside the measured number, compound 3's estimate shows no gap at the digits printed, within the range that was stated.
By their numbers in this assay, from the lowest: compounds 1, 2 and 3 (each within the scatter of the next).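

In this assay, 4-fluorophenyl in place of 2-fluorophenyl gives no change at the digits printed from compound 2 to compound 3 (within the scatter), and fluoro in place of chloro on an aromatic carbon gives no change at the digits printed from compound 1 to compound 3 (within the scatter). The earlier step changed the halogen and its place together, whereas these two steps separate them, and neither change alone moves the read-out on the amine nitrogen in a ring. No supporting evidence bears on this result.

From the compounds shown here alone, it stays open whether a trifluoromethyl or methoxy group in place of the halogen would give any effect at this dose.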